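Growth inhibition notes: compound 1 to compound 4

A few compounds are considered here, and "the series" means these few. Any claim that something is new, unique, unknown or untested is made for them only; others in the source may bear on it.

Measured so far:
compound 1 `COc1cc(SC)nc(NC(=S)NC(=O)c2c(-c3ccc(Cl)cc3Cl)noc2C)n1` — 69.2%
compound 2 `CSc1cc(C)nc(NC(=S)NC(=O)c2c(-c3ccc(Cl)cc3Cl)noc2C)n1` — 73.6%
compound 3 `Cc1onc(-c2ccc(Cl)cc2Cl)c1C(=O)/N=c1/nc2nc(Cl)cc(C)n2s1` — 70.2%

In a functional assay on the whole organism for inhibition, with Brassica napus as the target, with a stated time of 72 h, tested at 100 mg/L (a higher number here means more inhibition of growth at the concentration tested, a lower number less inhibition of growth), compound 1 has the lowest of the three numbers, but neither neighbour is clearly apart from it: compound 3 gives 70.2%, which is within the scatter of compound 1, and the step of a number 4.4 percentage points higher from compound 1 to compound 2 (within the scatter) is within the scatter as well. The three measured compounds therefore sit at one level in this assay.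

Compound 4 `Cc1cc(C)nc(NC(=S)NC(=O)c2c(-c3ccc(Cl)cc3Cl)noc2C)n1` is not yet measured. It differs from compound 1 in one place: 4,6-dimethylpyrimidin-2-yl in place of 4-methoxy-6-(methylsulfanyl)pyrimidin-2-yl on an amide-type nitrogen. For the measured compounds named here, the only measured step that bears on this change is a number 4.4 percentage points higher from compound 1 to compound 2 (within the scatter), which covers the methyl-in-place-of-methoxy part of the change and moved the number by an amount inside the scatter. Going by the values given here, no measured pair speaks to the methylsulfanyl-to-methyl part. The expected step is therefore none beyond the scatter: compound 4 is estimated to give 72% in this assay, within 60% to 83%, a step of a number 2.8 percentage points higher from compound 1 to compound 4 (within the scatter).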

Compound 4, percent growth inhibition at one concentration: 68%
Compound 4: middle estimate off by 4 percentage points, on the high side; the range from low to high includes it.
By their numbers in this assay, from the lowest: compounds 4, 1, 3 and 2 (each within the scatter of the next).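

In this assay, the full exchange of 4-methoxy-6-(methylsulfanyl)pyrimidin-2-yl for 4,6-dimethylpyrimidin-2-yl on the amide-type nitrogen gives a number 1.2 percentage points lower from compound 1 to compound 4 (within the scatter) and so leaves the number at the same level, even with both the methoxy and the methylsulfanyl gone. For the compounds shown here, the methylsulfanyl part, which no earlier pair covered, can now be read alone as methyl in place of methylsulfanyl on an aromatic carbon: a number 5.6 percentage points lower from compound 2 to compound 4 (within the scatter) and so also no change beyond the scatter. No measurement shown gives a reason for this flat response.

From the compounds shown here alone, whether an amine, a carboxylic acid or a longer chain such as butoxy on this pyrimidin-2-yl group would move the number beyond the scatter remains open. A single concentration also leaves open whether these compounds separate at lower doses.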